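Methoxy on the phenyl ring of compound 1

The source may hold more compounds than are shown below. What is called first, only, known or untested is meant among the compounds shown, and "the series" means these compounds.

In a physicochemical assay for pharmacokinetics, read by fluorescence and HPLC, with a stated time of 24 h (a higher number here means that the compound lasts longer, a lower number that the compound disappears faster), compound 1 `CC(C)(C)C1=C(C(=O)O)N2C(=O)/C(=C/c3ccccc3)C2O1` gives 0.21 h. Its double-bond isomer, compound 2 `CC(C)(C)C1=C(C(=O)O)N2C(=O)/C(=C\c3ccccc3)C2O1`, gives 0.17 h. For the measured compounds named here, the single measured step, a 1.2-fold lower number from compound 1 to compound 2 (0.09 log units; within the scatter), lies within the scatter, so compound 1 holds no clear place apart from compound 2.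

The next structure is compound 3 `COc1ccc(/C=C2/C(=O)N3C(C(=O)O)=C(C(C)(C)C)OC23)cc1`, which takes phenyl to 4-methoxyphenyl: methoxy in place of hydrogen on an aromatic carbon. Methoxy stands in place of hydrogen on an aromatic carbon, para to a large group. Going by the values given here, the measured step changes only the double bond from E to Z, so it bears on this change only loosely, and no measured step tests a substituent on the aromatic ring. No step beyond the scatter is therefore expected in this assay. The expected change is a 1.1-fold lower number from compound 1 to compound 3 (0.02 log units; within the scatter). For compound 3 the estimated half-life is 0.2 h, with an expected range of 0.1 h to 0.4 h.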

Compound 3, half-life: 0.2 h
Compound 3: the middle estimate sits on the measured number at the digits printed; measured number inside the range.
By their numbers in this assay, from the lowest: compounds 2, 3 and 1 (each within the scatter of the next).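

In this assay, methoxy in place of hydrogen on an aromatic carbon, para to a large group, gives a 1.1-fold lower number from compound 1 to compound 3 (0.02 log units; within the scatter). For the compounds shown here, compounds 1 and 2 tested only the geometry of the double bond, so this is the first evidence on the aromatic ring: at this place, the half-life shows no change beyond the scatter when hydrogen gives way to methoxy. Nothing available bears on the cause of this result.

With methoxy as the only ring substituent shown, it remains open whether an amine or a trifluoromethyl group at the same place would take the half-life beyond the scatter. Also open, as far as these compounds go, is whether methoxy would give the same result on the double-bond geometry of compound 2.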